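The compounds below may be only part of what the source reports. "The series", "measured", "known", "first", "only" and "open" are said of these compounds alone.

Measured so far in an assay on BTI cells for inhibition of Amine oxidase [flavin-containing] B (Homo sapiens), read by fluorescence and Amplex Red, with a stated time of 15 min; on this read-out higher numbers stand for weaker inhibition and lower numbers for stronger inhibition: compound 1 `CC(=O)N1N=C(c2ccc([N+](=O)[O-])cc2)O[C@@H]1c1ccc(Cl)c(Cl)c1` gives 7.61 nM; compound 2 `CC(=O)N1N=C(c2ccncc2)OC1c1ccc(Cl)c(Cl)c1` gives 69400 nM; compound 3 `CC(=O)N1N=C(c2ccc(Br)cc2)OC1c1ccc(Cl)c(Cl)c1` gives 67.7 nM.

Compound 3 stands second highest of the three numbers in this assay, between compound 1 and compound 2. For the measured compounds named here, the only single-point step measured is a 1000-fold lower number from compound 2 to compound 3 (3.01 log units; beyond the scatter), a large move that shows this position on the aryl group tolerates wide changes in outcome.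

Compound 4 `CC(=O)N1N=C(c2ccc([N+](=O)[O-])cc2)OC1c1ccc(Cl)c(Cl)c1` differs from compound 3 by nitro in place of bromo on an aromatic carbon. Going by the values given here, no measured step covers this exact exchange. The closest guide is compound 1, which carries the same nitro-substituted aryl group as compound 4 and the same shared core, differing only in that its configuration at the ring carbon is specified while compound 4 is drawn without it. The value of compound 1 in this assay against that of compound 3 shows the nitro-bearing analogue well below the bromo-bearing one, beyond the scatter.

For compound 4 a step of a 5.6-fold lower number from compound 3 to compound 4 (0.75 log units; beyond the scatter) is therefore expected, downward, toward the number of compound 1 but allowing for an unspecified configuration. The estimate for compound 4 is 12 nM, in the range 5 nM to 30 nM.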

Compound 4, half-maximal inhibitory concentration: 9.46 nM
For compound 4 the middle estimate is 1.3-fold (0.10 log units) above the measured one; the measured number falls inside the stated range.
By their numbers in this assay, from the lowest: compounds 1 and 4 (each within the scatter of the next); then compound 3; then compound 2.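

In this assay, nitro in place of bromo on an aromatic carbon para to a large group gives a 7.2-fold lower number from compound 3 to compound 4 (0.85 log units; beyond the scatter). For the compounds shown here, this is the first measured step between two substituents at this position on the six-membered aromatic ring of carbon only, and it shows that the outcome still shifts beyond the scatter once the 4-bromophenyl group is in place. The pair with the same atoms and bonds gives a 1.2-fold higher number from compound 1 to compound 4 (0.09 log units; within the scatter), so the drawn configuration at the saturated ring carbon shows no separation here, and nothing about the individual stereoisomers of compound 4 follows: the fact that one of compounds 1 and 4 is drawn with a defined configuration and the other without, at the place where they differ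

Open, as far as these compounds go, is how an amine, a carboxylic acid or a nitrile at this aromatic carbon would compare with nitro and bromo. Also open, from the compounds shown here alone, is the value of the form drawn S at the saturated ring carbon.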